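The source may hold more compounds than are shown below. What is called first, only, known or untested is meant among the compounds shown, and "the series" means these compounds.

Of the compounds shown here, two built on a shared core have been measured in an assay on HEK293 cells for inhibition of Steryl-sulfatase (Homo sapiens), tested at 0.1 uM; on this read-out lower numbers stand for a weaker effect and higher numbers for a stronger effect at the one concentration tested. Compound 1 (`CN(C)CCCN(Cc1ccccc1)c1cccc(C(=O)N2CCc3ccc(OS(N)(=O)=O)cc3C2)c1`) gives 23.8% in this assay. Compound 2 (`CN(C)CCN(Cc1ccccc1)c1ccc(C(=O)N2CCc3ccc(OS(N)(=O)=O)cc3C2)cc1`) gives 13.9% in this assay. The numbers of compound 1 and compound 2 lie within the usual scatter of repeated measurements of each other, so neither can be set apart from the other, and compound 1 simply stands alongside compound 2 in this assay. Compound 3 (`NS(=O)(=O)Oc1ccc2c(c1)CN(C(=O)c1cccc(N(CCCO)Cc3ccccc3)c1)CC2`) has not yet been measured. It differs from compound 1 in one place: hydroxy in place of dimethylamino on a saturated chain carbon, three bonds along the chain from a nitrogen on an aromatic ring. Going by the values given here, no measured pair shows what this change does, and compound 1 and compound 2 differ in more than one place, so no single step can be read from them. The expectation for compound 3 is a step of a number 5.8 percentage points lower from compound 1 to compound 3 (within the scatter), that is, nothing beyond the scatter. Compound 3 is expected to give 18% in this assay, within a range from 4% to 34%.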

Compound 3, a percentage reported as inhibition, at one concentration (the size of the read-out at that concentration, not a potency): 25.8%
Compound 3: the middle estimate sits 7.8 percentage points below what was measured; measured number inside the range.
By their numbers in this assay, from the lowest: compounds 2, 1 and 3 (each within the scatter of the next, the first and the last beyond it).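

Going by these compounds alone, replacing 3-(dimethylamino)propyl with 3-hydroxypropyl gives the first single-change comparison, and in this assay the change comes to a number 2 percentage points higher from compound 1 to compound 3 (within the scatter). At this position, then, the nitrogen-bearing dimethylamino group can give way to hydroxy, with its oxygen and its hydrogen-bond donor, without a shift that can be told apart from repeat-to-repeat variation at the one concentration tested. Nothing available explains why the read-out stays put.

From the compounds shown here alone, it remains open whether a different group at this position, such as a carboxylic acid, a primary amine or a methoxy group, would move the number beyond the scatter. Also open, going by these compounds, is what a longer chain carrying the hydroxy would do, and a single-concentration read-out cannot say how potency compares.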